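The source may report more compounds than this note shows. Statements on the series, on what has been measured and on what is new or still open speak of the compounds shown alone.

Of the compounds shown here, three sharing one core have been measured in an ADME assay on microsomes from liver (Mus musculus) for metabolic stability; on this read-out lower numbers stand for slow clearance and higher numbers for fast clearance. Compound 1 `CN1C(=O)C2=C(C1=O)N(CC(=O)Nc1ccc(-c3ccccc3)cn1)CCC2` gives 67 mL.min-1.g-1 in this assay. Compound 2 `CN1C(=O)C2=C(C1=O)N(CC(=O)Nc1ccc(-c3cccnc3)nc1)CCC2` gives 17 mL.min-1.g-1 in this assay. Compound 3 `CN1C(=O)C2=C(C1=O)N(CC(=O)Nc1ccc(-c3ccccn3)cc1)CCC2` gives 38 mL.min-1.g-1 in this assay. Among these three numbers compound 3 stands second highest: its number and that of compound 1 lie within the usual scatter of repeated measurements, so no order can be read between them, while the number of compound 2 lies beyond the scatter on the lower side, so compound 2 is cleared more slowly than compound 3.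

Compound 4 `CN1C(=O)C2=C(C1=O)N(CC(=O)Nc1ccc(-c3cccnc3)cc1)CCC2` has the same atoms as compound 3, joined differently: pyridin-3-yl in place of pyridin-2-yl on an aromatic carbon. For the measured compounds named here, no pair of measured compounds differs by exactly this change, so the size of the step has to be judged from the three numbers alone. That compound 1 at 67 mL.min-1.g-1 and compound 3 at 38 mL.min-1.g-1 sit within the scatter of each other, despite carrying different outer rings, suggests that swapping one pyridyl for the other changes little. The step of a 1.3-fold lower number from compound 3 to compound 4 (0.10 log units; within the scatter) is therefore expected to stay within the scatter, leaning slightly toward slower clearance. Compound 4 is accordingly estimated at 30 mL.min-1.g-1, with a range from 15 mL.min-1.g-1 to 60 mL.min-1.g-1.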

Compound 4, intrinsic clearance in microsomes: 48 mL.min-1.g-1
Estimate against measurement, compound 4: 1.6-fold (0.20 log units) below; measured number inside the range.
By their numbers in this assay, from the lowest: compound 2; then compounds 3, 4 and 1 (each within the scatter of the next).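

For the compounds shown here, this is the first pair of measured compounds that differ in one place only, so it gives the first direct reading of a change on an aromatic carbon para to a large group. In this assay, pyridin-3-yl in place of pyridin-2-yl gives a 1.3-fold higher number from compound 3 to compound 4 (0.10 log units; within the scatter), so no order can be read between the two compounds, and in this one pair, clearance does not separate these two ways of attaching the pyridine ring. Nothing available explains why the two compounds fall so close together, and no supporting measurement bears on this result.

The compounds shown leave open whether the same carbon would tolerate other groups equally well, such as pyridin-4-yl, or a saturated ring such as morpholine or piperidine, and so whether this position matters for clearance at all. They also leave open whether a small group added to the pyridine ring, such as a fluorine atom or a methoxy group, would move this assay beyond the scatter.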